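Replacing (Trifluoromethyl)sulfanyl with Ethyl: Compound 3 Expected

The compounds below may be only part of what the source reports. "The series", "measured", "known", "first", "only" and "open" are said of these compounds alone.

Compound 2 `Oc1nc2nonc2nc1Nc1ccc(SC(F)(F)F)cc1` carries (trifluoromethyl)sulfanyl on an aromatic carbon, and in an assay on mitochondria from L6 cells (Rattus norvegicus) for activation, with a stated time of 90 min (on this read-out lower numbers stand for an effect already at smaller amounts and higher numbers for an effect only at larger amounts of compound), compound 2 gives 1400 nM, the lower of the two numbers obtained so far. For the measured compounds named here, its only neighbour, compound 1 `Oc1nc2nonc2nc1Nc1ccc(OCc2ccccc2)cc1`, bears benzyloxy on that aromatic carbon, and in this assay compound 1 gives 2400 nM. Compound 3 `CCc1ccc(Nc2nc3nonc3nc2O)cc1` differs from compound 2 in one place: ethyl in place of (trifluoromethyl)sulfanyl on an aromatic carbon. Going by the values given here, the single measured step that bears on this exchange is a 1.7-fold lower number from compound 1 to compound 2 (0.23 log units; within the scatter), which also replaced one group by another on the same aromatic carbon and left the number within the scatter. Two different groups there gave numbers within the scatter of each other, and nothing in the data suggests ethyl would move the number beyond it, so no step beyond the scatter is expected in this assay. Compound 3 is therefore estimated at 1600 nM, within a range of 500 nM to 5000 nM, which means an expected step of a 1.1-fold higher number from compound 2 to compound 3 (0.06 log units; within the scatter).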

Compound 3, half-maximal effective concentration: 10700 nM
Beside the measured number, compound 3's estimate is 6.7-fold (0.83 log units) below it; the measured number lies above the stated range.
By their numbers in this assay, from the lowest: compounds 2 and 1 (each within the scatter of the next); then compound 3.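

Compound 1 and compound 2 had left the group on this aromatic carbon looking exchangeable, but compound 3 shows that the position does respond to what it carries: in this assay the exchange for ethyl gives a 7.6-fold higher number from compound 2 to compound 3 (0.88 log units; beyond the scatter), and the comparison with benzyloxy gives a 4.5-fold higher number from compound 1 to compound 3 (0.65 log units; beyond the scatter). Both steps are modest, yet ethyl stands apart from the two earlier groups, which remain within the scatter of each other. Nothing measured here accounts for this difference.

The compounds shown leave open whether the higher number belongs to ethyl alone or extends to other simple alkyl groups on this carbon. They also leave open whether a methoxy group, an amine or a longer chain would give a number near that of compound 2 or that of compound 3.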